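Fluoro to Isopropyl: What to Expect for Compound 4

A few compounds are considered here, and "the series" means these few. Any claim that something is new, unique, unknown or untested is made for them only; others in the source may bear on it.

Measured compounds in a functional assay on HEK293 cells for activation of melanin-concentrating hormone receptor 1 (Homo sapiens), read by inositol phosphate accumulation; a lower number here means that less compound is needed, a higher number that more compound is needed for the effect:
Compound 1 `CCCc1cc(N)c2cc(NC(=O)/C=C/c3ccc(F)cc3)ccc2n1` gives 200 nM.
Compound 2 `CC(C)(C)c1cc(N)c2cc(NC(=O)/C=C/c3ccc(C(F)(F)F)cc3)ccc2n1` gives 29 nM.
Compound 3 `CCC(C)c1cc(N)c2cc(NC(=O)/C=C/c3ccc(C(F)(F)F)cc3)ccc2n1` gives 44 nM.

Compound 1 stands highest of the three, so the most of it is needed for the effect; compound 3 and compound 2 both lie well below it. For the measured compounds named here, the only single-place step, a 1.5-fold higher number from compound 2 to compound 3 (0.18 log units; within the scatter), concerns another part of the shared core and says nothing about the change at hand. Compound 4 `CCCc1cc(N)c2cc(NC(=O)/C=C/c3ccc(C(C)C)cc3)ccc2n1` differs from compound 1 in one place: isopropyl in place of fluoro on an aromatic carbon. Compounds 2 and 3 differ from compound 1 in two places at once, so their lower numbers cannot be assigned to either change alone. For compound 4 a modest move is expected, a 2.0-fold lower number from compound 1 to compound 4 (0.30 log units; within the scatter), with wide uncertainty. The estimate for compound 4 is 100 nM, between 30 nM and 350 nM.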

Compound 4, half-maximal effective concentration: 520 nM
For compound 4 the middle estimate is 5.2-fold (0.72 log units) below the measured one; the whole stated range lies below it.
By their numbers in this assay, from the lowest: compounds 2 and 3 (each within the scatter of the next); then compound 1; then compound 4.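

In this assay, for the compounds shown here, isopropyl in place of fluoro gives a 2.6-fold higher number from compound 1 to compound 4 (0.41 log units; beyond the scatter), the first reading of this position taken alone. In compounds 2 and 3, the group here changes together with another part of the molecule, whereas this step shows that the position alone can shift the number and that 4-isopropylphenyl needs more compound than 4-fluorophenyl. Nothing shown here gives a reason for this step. From the compounds shown here alone, it remains open how trifluoromethyl would behave on the core of compound 1. Going by these compounds, the effect of a methoxy group or an amine at this carbon also remains open.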